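The compounds below may be only part of what the source reports. "The series", "measured", "known", "first", "only" and "open" are said of these compounds alone.

Measured so far in a functional assay on DU-145 cells (Homo sapiens) for cytotoxicity, read by MTT assay; a lower number here means a stronger inhibitor, a higher number a weaker inhibitor:

compound 1 `CC(O)(CS(=O)(=O)c1ccc(Cl)cc1)c1nc(-c2ccc([N+](=O)[O-])c(C(F)(F)F)c2)no1` gives 91000 nM
compound 2 `CC(O)(CSc1ccccc1)c1nc(-c2ccccc2)no1` is reported only as the limit > 100000 nM
compound 3 `CC(O)(CSc1ccc(Br)cc1)c1nc(-c2ccc([N+](=O)[O-])c(C(F)(F)F)c2)no1` gives 1600 nM

Compound 2 stands at the limit of the assay (the limit of > 100000 nM in this assay, at which 1 of the 3 values shown sits); the two other compounds carry a nitro and a trifluoromethyl on the aryl of the five-membered ring and differ from compound 2 in more than one place, so their values do not isolate any single change. Among the compounds with values here, the one measured step, a 57-fold lower number from compound 1 to compound 3 (1.75 log units; beyond the scatter), concerns the group on the saturated chain carbon and not the aryl on the ring, so it does not bear on the step to compound 4 `CC(O)(CSc1ccccc1)c1nc(-c2ccc(F)c(Cl)c2)no1`, where the change is 3-chloro-4-fluorophenyl in place of phenyl on an aromatic carbon.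

Within the data shown here, with no measured step to guide it, and the starting point known only as a limit, only a modest move is expected. Compound 4 is estimated at 50000 nM, with a range from 10000 nM to 200000 nM. That estimate means a step of an at least 2.0-fold lower number from compound 2 to compound 4 (0.30 log units; that floor lies within the scatter), which may still leave compound 4 reported as a limit.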

Compound 4, half-maximal inhibitory concentration: 5500 nM
For compound 4 the middle estimate is 9.1-fold (0.96 log units) above the measured one, outside the stated range (below it).
By their numbers in this assay, from the lowest: compound 3; then compound 4; then compound 1. At a limit, above all of these: compound 2.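

In this assay, the aryl on the aromatic carbon between two ring nitrogen atoms now shows its own effect on the read-out: with the rest of the molecule unchanged, 3-chloro-4-fluorophenyl in place of phenyl gives an at least 18-fold lower number from compound 2 to compound 4 (1.25 log units; beyond the scatter). Within the data shown here, the earlier step, a 57-fold lower number from compound 1 to compound 3 (1.75 log units; beyond the scatter), concerned the saturated chain carbon, so this is the first single change read at the aryl position. The size of the new step is only a floor, as compound 2 is known only as a limit: the limit of > 100000 nM in this assay, at which 1 of the 4 values shown sits.

Still open, from the compounds shown here alone, is whether the chlorine or the fluorine alone would carry the step, and how the aryl bearing nitro and trifluoromethyl compares with 3-chloro-4-fluorophenyl on an otherwise identical compound. Also open, going by these compounds, is how an amine or a carboxylic acid on that aryl would read in this assay.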